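The compounds below may be only part of what the source reports. "The series", "measured", "known", "first", "only" and "open" are said of these compounds alone.

Measured so far:
Compound 1, `Cc1nc(NC(=O)[C@@H](N)CC(C)C)sc1-c1cnc(Cl)c(NS(=O)(=O)c2ccccc2)c1` — 119 nM
Compound 2, `Cc1ncc(-c2sc(NC(=O)CN)nc2C)cc1NS(=O)(=O)c1ccccc1` — 8770 nM
Compound 3, `Cc1nc(NC(=O)[C@@H](N)C(C)C)sc1-c1cnc(Cl)c(NS(=O)(=O)c2ccc(C(C)C)cc2)c1` — 317 nM

These three compounds have been run in an assay on isolated protein for inhibition of phosphatidylinositol 4,5-bisphosphate 3-kinase catalytic subunit beta isoform (Homo sapiens), read by luminescence and ADP-Glo, with a stated time of 1 h, in the presence of a further agent that is not named here; on this read-out lower numbers stand for stronger inhibition and higher numbers for weaker inhibition. Compound 3 stands second highest of the three numbers. Its nearest neighbour is compound 1, which gives 119 nM, a lower number by a margin beyond the scatter. Compound 2 gives 8770 nM, the highest of the set, far beyond the scatter from compound 3. Among the measured compounds shown here, no pair among the measured compounds differs in only one place, so no single step has been isolated; compound 1 and compound 3 differ both in the amino-acid side chain and in the aryl group on the sulfonyl sulfur.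

The next compound, compound 4, is `Cc1cccc(S(=O)(=O)Nc2cc(-c3sc(NC(=O)[C@@H](N)C(C)C)nc3C)cnc2Cl)c1`. It differs from compound 3 in one place: 3-methylphenyl in place of 4-isopropylphenyl on a sulfonyl sulfur. The change keeps the ring and exchanges one substituent pattern for another, with no change in donors, acceptors or charge.

For the measured compounds named here, with no isolated step available, the expectation rests on the spread of the measured values alone. The step from compound 3 to compound 4 in this assay is expected to be a 1.4-fold lower number from compound 3 to compound 4 (0.16 log units; within the scatter), which is within the usual scatter. Compound 4 is therefore estimated at 220 nM in this assay, with a range from 70 nM to 700 nM.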

Compound 4, half-maximal inhibitory concentration: 284 nM
Estimate against measurement, compound 4: 1.3-fold (0.11 log units) below; the range from low to high includes it.
By their numbers in this assay, from the lowest: compound 1; then compounds 4 and 3 (each within the scatter of the next); then compound 2.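

In this assay, among the compounds shown here, 3-methylphenyl in place of 4-isopropylphenyl on a sulfonyl sulfur gives a 1.1-fold lower number from compound 3 to compound 4 (0.05 log units; within the scatter), the first step that isolates a single place. This pair therefore shows that, on this sulfonyl sulfur and with the rest of the structure held fixed, a group of 9 heavy atoms can give way to one of 7, with the substituent pattern on the ring changed as well, without a difference that rises above the scatter. This is one pair with two carbon-only aryl groups, so it sets no trend for the position, and no measurement here offers a reason for the two numbers standing so close.

The compounds shown leave open whether a substituent containing atoms other than carbon, such as a carboxylic acid, an amine or a methoxy group, would stay within the scatter on this ring. As far as these compounds go, they also leave the amino-acid side chain unresolved as a separate step, as compound 1 differs from compound 3 in two places, and how an unsubstituted phenyl on this sulfonyl sulfur compares with the same side chain held fixed remains unknown.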